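Notes on the step from compound 3 to compound 4

This account rests on a few compounds, and the source may have more. Where it says the series, first, only, none or still open, it means among the compounds named here.

Three members of the series have been measured in a physicochemical assay for lipophilicity, measured as octanol-water partition; on this read-out lower numbers stand for lower lipophilicity and higher numbers for higher lipophilicity. Compound 1 `CC1=C(C(=O)OCc2ccccn2)C(c2ccc(Br)cc2)C2=C(CCCC2=O)N1` gives 2.42, compound 2 `CC1=C(C(=O)OCc2ccccn2)C(c2ccc(Cl)cc2)C2=C(CCCC2=O)N1` gives 2.24 and compound 3 `CC1=C(C(=O)OCc2ccccn2)C(c2ccc(C#N)cc2)C2=C(CCCC2=O)N1` gives 1.73. Compound 3 stands lowest of the three; its nearest neighbour is compound 2 and the furthest is compound 1, both gaps lying beyond the scatter. Among the measured compounds shown here, the measured steps so far are these: a number 0.18 log units lower from compound 1 to compound 2 (within the scatter), with chloro in place of bromo on an aromatic carbon; a number 0.69 log units lower from compound 1 to compound 3 (beyond the scatter), with cyano in place of bromo on an aromatic carbon; and a number 0.51 log units lower from compound 2 to compound 3 (beyond the scatter), with cyano in place of chloro on an aromatic carbon.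

Compound 4 `CC1=C(C(=O)OCc2ccccn2)C(c2ccc(O)cc2)C2=C(CCCC2=O)N1` has not yet been measured. Its difference from compound 3 is this: hydroxy in place of cyano on an aromatic carbon. For the measured compounds named here, none of the measured steps involves a hydroxy group, so none bears directly on this change; the two steps that introduce cyano show only that cyano gave the lowest number of the set. Without a direct guide the step is expected to be small, a number 0.13 log units lower from compound 3 to compound 4 (within the scatter), with no direction claimed beyond the scatter. Compound 4 is therefore estimated at 1.6, with a range from 1.2 to 2.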

Compound 4, partition coefficient: 1.58
Compound 4: middle estimate off by 0.02 log units, on the high side; measured number inside the range.
By their numbers in this assay, from the lowest: compounds 4 and 3 (each within the scatter of the next); then compounds 2 and 1 (each within the scatter of the next).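

In this assay, the first hydrogen-bond donor at this aromatic carbon leaves the read-out unseparated from that of the nitrile: the step is a number 0.15 log units lower from compound 3 to compound 4 (within the scatter), even though cyano gives way to a group with one heavy atom fewer and a different atom type. Among the compounds shown here, the halogens stay apart from hydroxy, with a number 0.66 log units lower from compound 2 to compound 4 (beyond the scatter) and a number 0.84 log units lower from compound 1 to compound 4 (beyond the scatter), so the four compounds now fall into two sets at this position: hydroxy and cyano in one, chloro and bromo in the other, with no compound among the four going against that split. No measured information bears on why two such different groups give values this close.

From the compounds shown here alone, whether an amine, a carboxylic acid or a methoxy group on the same aromatic carbon would join the hydroxy and cyano set, the halogen set or neither remains open. The compounds shown also leave open whether the close match between hydroxy and cyano would hold with the ester chain or the rest of the shared core changed.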